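Bromo for Trifluoromethyl on the Benzyl Ring

This account rests on a few compounds, and the source may have more. Where it says the series, first, only, none or still open, it means among the compounds named here.

Measured compounds:
compound 1 `O=S(=O)(NCCCNCc1ccc(Cl)c(C(F)(F)F)c1)c1cc(C(F)(F)F)cc(C(F)(F)F)c1`: 9100 nM
compound 2 `O=S(=O)(NCCCNCc1ccc(C(F)(F)F)cc1)c1cc(C(F)(F)F)cc(C(F)(F)F)c1`: 2000 nM

Among the compounds with values here, in a functional assay on Capan-2 cells (Homo sapiens) for inhibition, read by MTT assay, with a stated time of 72 h (on this read-out lower numbers stand for stronger inhibition of growth and higher numbers for weaker inhibition of growth), compound 2 gives the lowest of the two numbers; its only neighbour is compound 1, and the step of a 4.6-fold lower number from compound 1 to compound 2 (0.66 log units; beyond the scatter) separates them. Compound 3 `O=S(=O)(NCCCNCc1ccc(Br)cc1)c1cc(C(F)(F)F)cc(C(F)(F)F)c1` differs from compound 2 by bromo in place of trifluoromethyl on an aromatic carbon. Within the data shown here, no measured step makes this same exchange; the single step of a 4.6-fold lower number from compound 1 to compound 2 (0.66 log units; beyond the scatter) changes the same benzyl ring but swaps a different pair of groups, so it bears on the question only loosely. For compound 3 the author therefore expects a step of a 1.3-fold higher number from compound 2 to compound 3 (0.10 log units; within the scatter), not beyond the scatter. For compound 3 the estimate is 2500 nM, with a range from 900 nM to 7000 nM.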

Compound 3, concentration for 50% growth inhibition: 2000 nM
The estimate for compound 3 lay 1.3-fold (0.10 log units) above the measured number; low and high end bracket the measured number.
By their numbers in this assay, from the lowest: compounds 2 and 3 (each within the scatter of the next); then compound 1.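

In this assay, replacing trifluoromethyl with bromo on this aromatic carbon gives no change at the digits printed from compound 2 to compound 3 (within the scatter), so the reading here does not depend on trifluoromethyl, even though 4 heavy atoms give way to 1. The 4-bromophenyl group also shows a 4.6-fold lower number from compound 1 to compound 3 (0.66 log units; beyond the scatter), a step that matches the one already seen with 4-(trifluoromethyl)phenyl. Nothing available explains why the two groups read alike.

As far as these compounds go, whether an amine, a carboxylic acid or a nitrile on this carbon would give a similar number remains open, as does the effect of a longer chain in the shared core.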